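The source may report more compounds than this note shows. Statements on the series, on what has been measured and on what is new or still open speak of the compounds shown alone.

Compound 1 `CC(C)(C)OC(=O)N1CCC(O[C@H]2CC[C@H](Oc3ccc(S(C)(=O)=O)c(F)c3)CC2)CC1` gives 109% in a functional assay on isolated protein for agonist activity at Glucose-dependent insulinotropic receptor (Rattus norvegicus), read by HTRF and cAMP accumulation; a lower number here means a smaller maximal response, a higher number a larger maximal response.
Compound 2 `CS(=O)(=O)c1cnc(O[C@H]2CC[C@H](OC3CCN(C(=O)OC4CCOC4)CC3)CC2)cn1` gives 109% in this assay.

On these numbers compound 2 stands level with compound 1; the gap between the two lies within the scatter, so neither can be placed above the other. Both reach a maximal response at or a little above the reference in this assay.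

Compound 3 `CC(F)Cc1nc(CN2CCC(O[C@H]3CC[C@H](Oc4cnc(S(C)(=O)=O)cn4)CC3)CC2)no1` has not yet been measured in this assay. It differs from compound 2 in a single place: (5-(2-fluoropropyl)-1,2,4-oxadiazol-3-yl)methyl in place of ((oxolan-3-yl)oxy)carbonyl on an amine nitrogen in a ring. For the measured compounds named here, no step between measured compounds covers a change of this kind, so only the two values already seen can guide the expectation. Because compound 2 gives 109%, and because compound 1, carrying a different group on the same ring nitrogen, gives 109%, the maximal response is expected to stay in the same region, and the step of a number 4 percentage points lower from compound 2 to compound 3 (within the scatter) is estimated as none beyond the scatter. Compound 3 is therefore expected to give about 105%, with a range from 90% to 120%.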

Compound 3, largest response reached (Emax), in percent of the reference or control that the assay uses: 114%
For compound 3 the middle estimate is 9 percentage points below the measured one, within the range that was stated.
By their numbers in this assay, from the lowest: compounds 1, 2 and 3 (each within the scatter of the next).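

In this assay the change on the amine nitrogen in the six-membered ring gives a number 5 percentage points higher from compound 2 to compound 3 (within the scatter) and so leaves the maximal response where it was. At this position, the maximal response therefore holds when the carbonyl-linked ((oxolan-3-yl)oxy)carbonyl gives way to (5-(2-fluoropropyl)-1,2,4-oxadiazol-3-yl)methyl, which swaps a five-membered non-aromatic ring for a five-membered aromatic ring with 3 hetero atoms. Nothing at hand explains why the response holds across this change.

The compounds shown leave open whether the fluorine in the side chain matters, since a plain propyl chain on the same oxadiazole does not appear among them. They also leave open how the maximal response behaves with a smaller group on this nitrogen, such as acetyl or methyl.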